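This account rests on a few compounds, and the source may have more. Where it says the series, first, only, none or still open, it means among the compounds named here.

Measured in a functional assay on RAW264.7 cells (Mus musculus) for inhibition, read by Griess assay, with stated times of 3 h and 24 h; a higher number here means a weaker inhibitor, a lower number a stronger inhibitor:
Compound 1 `C=C1CC[C@H]2[C@@](C)(CC[C@@H](OC(=O)c3cccnc3)[C@@]2(C)NC=O)[C@@H]1/C=C/C1=CCOC1=O`: > 50000 nM
Compound 2 `C=C1CC[C@H]2[C@@](C)(CC[C@@H](OC(=O)[C@H]3CCCN3)[C@@]2(C)NC=O)[C@@H]1/C=C/C1=CCOC1=O`: > 50000 nM

Both entries are limits of the assay, not numbers. Compound 2 thus stands at the limit of > 50000 nM in this assay, at which 2 of the 2 values shown sit. Compound 3 `C=C1CC[C@H]2[C@@](C)(CC[C@@H](OC(=O)CCCC[C@@H]3CCSS3)[C@@]2(C)NC=O)[C@@H]1/C=C/C1=CCOC1=O` departs from compound 2 on a carbonyl carbon: a group of 9 heavy atoms (7 carbon, 2 sulfur; one five-membered non-aromatic ring with 2 hetero atoms) in place of a group of 5 heavy atoms (4 carbon, 1 nitrogen; one five-membered non-aromatic ring with 1 hetero atom), on a carbonyl carbon. For the measured compounds named here, the one measured step at this place, a step that the two limits leave unreadable from compound 1 to compound 2, offers no size to carry over. Any expectation in this assay is therefore loose: a small move towards stronger inhibition, with another limit quite possible. The expected step is an at least 1.6-fold lower number from compound 2 to compound 3 (0.22 log units; that floor lies within the scatter). Compound 3 is expected near 30000 nM, with an estimated range of 6000 nM to 50000 nM.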

Compound 3, half-maximal inhibitory concentration: > 50000 nM
Compound 3: a limit, no number; the forecaster's own chance of this, stated with the estimate: 55%; middle value at least 1.6-fold (0.22 log units) from the limit.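

For the compounds shown here, compound 3 also ends at a limit, not a number, so no step among compound 1, compound 2 and compound 3 can be read: the limit of > 50000 nM in this assay, at which 3 of the 3 values shown sit. The compounds shown leave open whether any group on this carbonyl carbon changes inhibition.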